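Moving the fluorine on the phenyl ring of compound 3

A few compounds are considered here, and "the series" means these few. Any claim that something is new, unique, unknown or untested is made for them only; others in the source may bear on it.

Of the compounds shown here, three sharing one core have been tested in a functional assay on cardiac atrium for agonist activity at histamine H2 receptor (Cavia porcellus); a lower number here means a smaller maximal response, a higher number a larger maximal response. Compound 1 `Cc1ccc(C(CC/N=C(\N)NCCCc2c[nH]cn2)c2ccccn2)cc1` reaches 1 in this assay, the same as the reference agonist. Compound 2 `N/C(=N\CCC(c1ccc(O)cc1)c1ccccn1)NCCCc1c[nH]cn1` reaches 1 in this assay, and the step of no change at the digits printed from compound 1 to compound 2 (within the scatter) shows that replacing one group by another on the aromatic carbon of the phenyl ring left the maximal response untouched. Compound 3 `N=C(NCCCc1c[nH]cn1)NCCC(c1ccc(F)cc1)c1ccccn1` reaches 1 in this assay, which sits level with compounds 1 and 2 within the scatter, so all three are full agonists in this assay.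

Compound 4 `N=C(NCCCc1c[nH]cn1)NCCC(c1ccccn1)c1ccccc1F` has not yet been measured. Its difference from compound 3 is 2-fluorophenyl in place of 4-fluorophenyl on a saturated chain carbon bound to an aromatic carbon and a saturated chain carbon. Going by the values given here, no measured step moves a group from one ring position to another, so the only guide is the step from compound 1 to compound 2, which changed the group on the phenyl ring without shifting the maximal response. On that basis the step of no change at the digits printed from compound 3 to compound 4 (within the scatter) is expected to lie within the scatter, with no change beyond it. The estimated intrinsic activity of compound 4 in this assay is 1, within a range from 0.85 to 1.05.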

Compound 4, intrinsic activity: the largest response reached, as a fraction of the reference agonist's: 1
Estimate against measurement, compound 4: no gap at the digits printed; measured number inside the range.
By their numbers in this assay, from the lowest: compounds 1, 2, 3 and 4 (each within the scatter of the next).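

In this assay, going by these compounds alone, the new step is the first to change where a group sits on the phenyl ring rather than which group it carries: with 2-fluorophenyl in place of 4-fluorophenyl, on a saturated chain carbon bound to an aromatic carbon and a saturated chain carbon, the result is no change at the digits printed from compound 3 to compound 4 (within the scatter) for the maximal response. Within the data shown here, the earlier compounds showed only that exchanging one group for another on this ring left that response level, whereas this pair, with the same atoms joined differently, shows that for fluorine the change of place leaves it level too. No measurement shown here explains why the response holds across this change.

With all four compounds level, this read-out gives no difference by which to rank the changes, and it says nothing about how much of each compound is needed to reach that response. On these data alone, whether a trifluoromethyl group or an amine on the phenyl ring, or a longer chain in the shared core, would keep the maximal response level remains open.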